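Swapping a halogenated benzyl ether and checking liver cell toxicity

This account rests on a few compounds, and the source may have more. Where it says the series, first, only, none or still open, it means among the compounds named here.

Compound 1, `Cc1cc(Br)cc(OC(c2ccc(Cl)cc2)c2cnc(NC(=O)OC(C)(C)C)s2)c1`, is measured in an ADME assay on HepG2 2.2.15 cells (Homo sapiens) for cytotoxicity (on this read-out lower numbers stand for higher toxicity in this test and higher numbers for lower toxicity in this test), and gives a limit of the assay, > 50000 nM.
Compound 2, `CC(C)(C)OC(=O)Nc1ncc(C(Oc2ccc(Cc3ccccc3)cc2)c2ccc(Cl)cc2)s1`, gives in this assay a limit as well, > 50000 nM.
Compound 3, `O=C(Nc1ncc(C(OCc2ccc(Br)cc2)c2ccccc2)s1)c1cccs1`, is reported in this assay only as "not toxic" (no number reported).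

So compound 3 stands without a single number, next to two neighbours that both sit at the limit of > 50000 nM in this assay, at which 2 of the 3 values shown sit. Compound 4, `O=C(Nc1ncc(C(OCc2ccc(F)cc2F)c2ccccc2)s1)c1cccs1`, is not yet measured in this assay. It differs from compound 3 by 2,4-difluorophenyl in place of 4-bromophenyl on a saturated chain carbon bound to an oxygen on a saturated carbon. With every result so far at or beyond the ceiling of the test, the expectation is that this change makes no step beyond the usual scatter in this assay. Compound 4 is therefore estimated at 60000 nM, within 20000 nM to 200000 nM, most likely again reported as a limit.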

Compound 4, half-maximal cytotoxic concentration: "not toxic" (no number reported)
Compound 4: no number reported; there is nothing to compare the estimate with.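

Compound 3 and compound 4 are both reported in this assay only as "not toxic", so no step can be read between them. What concentration would make any of these compounds toxic stays open.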